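Methyl on the pyridazinone core: second ring position

A few compounds are considered here, and "the series" means these few. Any claim that something is new, unique, unknown or untested is made for them only; others in the source may bear on it.

Compound 1 `C/N=C(/NC#N)NCCCCCn1nc(-c2ccccc2)ccc1=O` gives 47.6% in a functional assay on the whole organism with Rattus norvegicus as the target, at a dose of 100 mg/kg (on this read-out higher numbers stand for more inhibition at the one dose given (going by the name of the read-out) and lower numbers for less inhibition), the highest of the two numbers recorded there. Compound 2 `C/N=C(/NC#N)NCCCCCn1nc(-c2ccccc2)c(C)cc1=O` gives 28.5%; the step of a number 19.1 percentage points lower from compound 1 to compound 2 (beyond the scatter) is a methyl in place of hydrogen on an aromatic carbon. Compound 3 `C/N=C(/NC#N)NCCCCCn1nc(-c2ccccc2)cc(C)c1=O` carries the same kind of change at another ring carbon: methyl in place of hydrogen on an aromatic carbon. For the measured compounds named here, only the step to compound 2 bears on this, and it is a different position, so the expectation leans on a single modest drop. A comparable downward step is expected, a number 14.6 percentage points lower from compound 1 to compound 3 (beyond the scatter), with wide uncertainty. Compound 3 is therefore estimated at 33%, between 15% and 50%.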

Compound 3, a percentage reported as inhibition, in the whole organism at one dose (the size of the read-out at that dose, not a potency): 33.8%
For compound 3 the middle estimate is 0.8 percentage points below the measured one; the range from low to high includes it.
By their numbers in this assay, from the lowest: compounds 2 and 3 (each within the scatter of the next); then compound 1.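

In this assay the methyl on the aromatic carbon two atoms from the ring nitrogen gives a number 13.8 percentage points lower from compound 1 to compound 3 (beyond the scatter) so the loss is not confined to one ring carbon. Compound 2 at 28.5% and compound 3 at 33.8% lie within the scatter of each other and these two methyl positions are not separated on this read-out. No measurement here accounts for the loss.

As far as these compounds go, whether an ethyl, a methoxy or an amine at this same carbon would track with methyl remains open. Each number also comes from a single dose, so potency stays undefined.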